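The source may hold more compounds than are shown below. What is called first, only, known or untested is meant among the compounds shown, and "the series" means these compounds.

Compound 3 `CCOc1ccc(-n2nncc2CN2C(=O)C3(C(C#N)=C(N)Oc4c(N)cc5nc6ccccc6nc5c43)c3ccccc32)cc1` gives the lowest of the two numbers in a functional assay on MCF7 cells (Homo sapiens) for antiproliferative activity, read by MTT assay, with a stated time of 48 h (on this read-out higher numbers stand for weaker inhibition and lower numbers for stronger inhibition), 26800 nM. Compound 2 `N#CC1=C(N)Oc2c(c3nc4ccccc4nc3c3ccccc23)C12C(=O)N(Cc1cnnn1-c1cccc(Cl)c1)c1ccccc12` sits nearest, and in this assay compound 2 gives 43600 nM, a gap within the scatter. Compound 1 `N#CC1=C(N)Oc2c(c3nc4ccccc4nc3c3ccccc23)C12C(=O)N(Cc1cnnn1-c1ccccc1Cl)c1ccccc12` reaches the limit of > 50000 nM in this assay, at which 1 of the 3 values shown sits, and is recorded only as a limit, > 50000 nM. Among the measured compounds shown here, the one step between measured compounds, an at least 1.1-fold lower number from compound 1 to compound 2 (0.05 log units; that floor lies within the scatter), moves the chlorine on the aryl group at the triazole nitrogen. Compound 4 `Cc1cc(C)c(-n2nncc2CN2C(=O)C3(C(C#N)=C(N)Oc4c(N)cc5nc6ccccc6nc5c43)c3ccccc32)c(C)c1` is compound 3 with 2,4,6-trimethylphenyl in place of 4-ethoxyphenyl on an aromatic nitrogen. For the measured compounds named here, that step also only reshapes the aryl group on the same nitrogen, and no measured pair exchanges an ethoxy for methyls, so the step of a 1.1-fold higher number from compound 3 to compound 4 (0.05 log units; within the scatter) is expected to stay within the scatter. Compound 4 is estimated at 30000 nM, between 12000 nM and 70000 nM.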

Compound 4, half-maximal inhibitory concentration: > 50000 nM
Compound 4: only a limit was reported; the forecaster's own chance of this, stated with the estimate: 20%; middle value at least 1.6-fold (0.22 log units) away from the limit.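

With 2,4,6-trimethylphenyl in place of 4-ethoxyphenyl on the triazole nitrogen, this assay gives an at least 1.8-fold higher number from compound 3 to compound 4 (0.27 log units; that floor lies within the scatter). Compound 4 gives > 50000 nM, which is a limit, and it is not alone there: the limit of > 50000 nM in this assay, at which 2 of the 4 values shown sit. Unlike the chlorine move between compounds 1 and 2, this change replaces the whole substitution of the aryl group, and again only a floor can be read.

The compounds shown leave open whether the loss of the ethoxy or the arrival of the methyls drives this step. They also leave open how an amine or a carboxylic acid on this aryl group would read.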